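The compounds below may be only part of what the source reports. "The series", "measured", "known", "first", "only" and "open" are said of these compounds alone.

Among the measured compounds shown here, compound 2, `CCCCn1cc(C(=O)NCc2ccc(OC)cc2)c(=O)c2cc(F)c(N3CCC(C(N)=O)CC3)cc21`, stands as the one compound of the pair with an actual number in an ADME assay on J774.1 cells (Mus musculus) for cytotoxicity, read by resazurin assay, with a stated time of 48 h; on this read-out lower numbers stand for stronger inhibition and higher numbers for weaker inhibition: compound 2 gives 40800 nM. Compound 1, `COc1ccc(CNC(=O)c2cn(C3CC3)c3cc(N4CCC(C(N)=O)CC4)c(F)cc3c2=O)cc1`, reaches only a limit, giving > 100000 nM in this assay. Between the two, an at least 2.4-fold lower number from compound 1 to compound 2 (0.38 log units; beyond the scatter), though with compound 1 sitting at the limit of > 100000 nM in this assay, at which 1 of the 2 values shown sits, the size of that step is known only as a lower bound. Compound 3, `CCCCn1cc(C(=O)NCc2ccc(O)cc2)c(=O)c2cc(F)c(N3CCC(C(N)=O)CC3)cc21`, differs from compound 2 by hydrogen in place of methyl on an oxygen on an aromatic ring. For the measured compounds named here, no measured step touches this oxygen; the single step in hand alters the group on the aromatic nitrogen and says nothing about the methyl on the oxygen. With nothing to lean on, the expectation for compound 3 in this assay is a step of a 1.1-fold higher number from compound 2 to compound 3 (0.04 log units; within the scatter), that is, no change beyond the scatter. Compound 3 is therefore estimated at 45000 nM, with a range of 18000 nM to 100000 nM.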

Compound 3, half-maximal inhibitory concentration: 41600 nM
Compound 3: the middle estimate sits 1.1-fold (0.03 log units) above what was measured; the measured number falls inside the stated range.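

Taking the methyl off the oxygen on the aromatic ring gives a 1.0-fold higher number from compound 2 to compound 3 (0.01 log units; within the scatter) in this assay, so this position, which the earlier pair did not touch, now has a first reading, and for this one change that reading stays within the scatter. The earlier step concerned only the group on the aromatic nitrogen; with butyl on that nitrogen, the 4-methoxybenzyl and 4-hydroxybenzyl groups give numbers that cannot be told apart. Nothing shown here gives a reason for this reading.

From the compounds shown here alone, whether an ethyl or a longer chain on this oxygen, or an amine in place of the hydroxy, would read the same stays open. So does whether the same exchange would read alike with cyclopropyl on the aromatic nitrogen, where compound 1 offers only a limit.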